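From allyl to 2,5-dichlorobenzyl on the sulfur

A few compounds are considered here, and "the series" means these few. Any claim that something is new, unique, unknown or untested is made for them only; others in the source may bear on it.

Compound 1 (`Cc1cc(N2CC[C@@H](C)[C@@H](N(C)c3ncnc4[nH]ccc34)C2)n2nc(SCc3ccccc3Br)nc2n1`) gives > 100000 nM as a limit.
Compound 2 (`C=CCSc1nc2nc(C)cc(N3CC[C@@H](C)[C@@H](N(C)c4ncnc5[nH]ccc45)C3)n2n1`) gives > 100000 nM as a limit.

In a toxicity assay on GES1 cells (Homo sapiens) for inhibition, read by MTT assay, with a stated time of 72 h (a higher number here means a weaker inhibitor, a lower number a stronger inhibitor), compound 2 stands at > 100000 nM as a limit and not as a number. The two measured compounds share one position, the limit of > 100000 nM in this assay, at which 2 of the 2 values shown sit, and nothing finer.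

Compound 3 (`Cc1cc(N2CC[C@@H](C)[C@@H](N(C)c3ncnc4[nH]ccc34)C2)n2nc(SCc3cc(Cl)ccc3Cl)nc2n1`) differs from compound 2 at a single place (2,5-dichlorophenyl in place of vinyl on a saturated chain carbon bound to a sulfur) with 2,5-dichlorophenyl in place of vinyl on a saturated chain carbon bound to a sulfur.

Among the compounds with values here, the one measured step that bears on this change is a step that the two limits leave unreadable from compound 1 to compound 2 at that same place, so it offers no size to carry over. Compound 1, with 2-bromophenyl at that place, shows > 100000 nM as a limit. No readable change in this assay is expected in either direction. The step expected is a number no higher from compound 2 to compound 3 (the limit leaves the size open) as an estimate and not a measurement. Compound 3 is expected near 100000 nM with an estimated range from 40000 nM to 200000 nM and is more likely than not to come back as a limit again.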

Compound 3, half-maximal inhibitory concentration: 87500 nM
The estimate for compound 3 lay 1.1-fold (0.06 log units) above the measured number, within the range that was stated.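

In this assay, within the data shown here, compound 3 is the only one of the three compounds with a number rather than a limit, which gives this place on the sulfur its first readable value. Setting 2,5-dichlorophenyl in place of vinyl on a saturated chain carbon bound to a sulfur gives an at least 1.1-fold lower number from compound 2 to compound 3 (0.05 log units; that floor lies within the scatter), and setting it in place of 2-bromophenyl at that same place gives an at least 1.1-fold lower number from compound 1 to compound 3 (0.05 log units; that floor lies within the scatter). Both steps are only floors, so they do not separate compound 3 from the other two compounds, the step between those two cannot be read, and the position remains defined mostly by a shared limit: the limit of > 100000 nM in this assay, at which 2 of the 3 values shown sit.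

The compounds shown leave open whether the true gap between compound 3 and either compound 1 or compound 2 reaches beyond the scatter. They also leave open whether a different kind of group on the sulfur, such as a longer alkyl chain, or a chain ending in an amine or a carboxylic acid, would give a clearly readable step in this assay.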